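The source may report more compounds than this note shows. Statements on the series, on what has been measured and on what is new or still open speak of the compounds shown alone.

Measured compounds in a physicochemical assay for solubility, read by turbidimetry, measured as kinetic solubility, at pH 6.8; on this read-out lower numbers stand for lower solubility and higher numbers for higher solubility:

- compound 1, `CC1SC(c2cccc(C(=O)NCCCCc3ccccc3)c2)N(c2ccc(C3CC3)cc2)C1=O`: 10000 nM
- compound 2, `O=C(NCCCCc1ccccc1)c1cccc(C2SCC(=O)N2c2cccc(F)c2)c1`: 10000 nM
- compound 3, `C#Cc1cc(C(=O)NCCCCc2ccccc2)cc(C2SCC(=O)N2c2ccccc2OC)c1`: 10000 nM

In this assay compound 2 gives 10000 nM. On the numbers shown, compound 2 stands level with compound 1 and with compound 3; the gap to compound 1 and the gap to compound 3 both lie within the scatter, so no order among the three can be read from these values. All three share the same core carrying the amide to the four-carbon chain ending in a phenyl ring, and differ only in the groups on the aromatic rings at either end.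

The unmeasured compound 4, `Cc1cccc(N2C(=O)CSC2c2cccc(C(=O)NCCCCc3ccccc3)c2)c1`, is reached from compound 2 by one change: methyl in place of fluoro on an aromatic carbon. Among the measured compounds, no pair differs in exactly one place, so no step of this kind has been seen before.

Given that compound 1, compound 2 and compound 3 all sit at the same value despite differing groups on both aromatic rings, compound 4 is expected to fall within the scatter of compound 2, with the step of no change at the digits printed from compound 2 to compound 4 (within the scatter) expected to be small and in no particular direction. Compound 4 is therefore estimated at 10000 nM, in a range from 5000 nM to 20000 nM.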

Compound 4, solubility: 10000 nM
Beside the measured number, compound 4's estimate shows no gap at the digits printed; low and high end bracket the measured number.
By their numbers in this assay, from the lowest: compounds 1, 2, 3 and 4 (each within the scatter of the next).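

In this assay, methyl in place of fluoro on an aromatic carbon, meta to a large group, gives no change at the digits printed from compound 2 to compound 4 (within the scatter). Within the data shown here, this is the first step that changes one place only, so the exchange of these two groups at this carbon can now be read directly, which no earlier pair of compounds allowed. The step is a single observation at a single position, and no further data are available to account for it.

On these data alone, whether an amine or a carboxylic acid at this same carbon would read the same in this assay remains open. Also open, as far as these compounds go, is whether 3-fluorophenyl to 3-methylphenyl would give a similar step with a shorter chain in place of the one ending in the phenyl ring.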